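Swapping a Sulfone Chain for a Nitrile Chain

The source may hold more compounds than are shown below. What is called first, only, known or untested is meant among the compounds shown, and "the series" means these compounds.

The measured compounds, all tested in an ADME assay on liver (Homo sapiens) for metabolic stability; on this read-out higher numbers stand for a longer-lived compound and lower numbers for a shorter-lived compound:
Compound 1 `N#CCCCn1c(CN2C(=O)/C(=N/OCCF)c3cccnc32)nc2ccccc21` gives 0.917 h.
Compound 2 `CS(=O)(=O)CCCn1c(CN2C(=O)/C(=N/OCCF)c3cccnc32)nc2ccccc21` gives a result that is a limit of the assay rather than a number, > 1.66 h.
Compound 3 `CS(=O)(=O)CCCn1c(CN2C(=O)/C(=N/OCc3ccc(S(C)(=O)=O)cc3)c3cnccc32)nc2ccccc21` gives 3.33 h.

Compound 2 and compound 1 differ in one place: cyano in place of methylsulfonyl on a saturated chain carbon, three bonds along the chain from an aromatic nitrogen. The step that this change made is an at least 1.8-fold lower number from compound 2 to compound 1 (0.25 log units; that floor lies within the scatter), and the floor of that step is set only by the limit of > 1.66 h in this assay, at which 1 of the 3 values shown sits, so its true size is not pinned down.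

Compound 3 carries the same chain as compound 2 but sits on a different core; the difference between the two cores is not broken down here. Among the numbers measured, compound 3 stands highest, and its gap to compound 1 lies beyond the scatter.

Compound 4 `CS(=O)(=O)c1ccc(CO/N=C2/C(=O)N(Cc3nc4ccccc4n3CCCC#N)c3ccncc32)cc1` is not yet measured. Among the measured compounds shown here, it differs from compound 3 by cyano in place of methylsulfonyl on a saturated chain carbon, three bonds along the chain from an aromatic nitrogen, which is the same change, at the same place, as the one from compound 2 to compound 1. It is expected that this change lowers the value of compound 4 in this assay by about a 2.2-fold lower number from compound 3 to compound 4 (0.35 log units; beyond the scatter), resting on compound 2 and compound 1 and their step of an at least 1.8-fold lower number from compound 2 to compound 1 (0.25 log units; that floor lies within the scatter). For compound 4 the estimate is therefore 1.5 h, expected to fall between 0.8 h and 3 h.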

Compound 4, half-life: 0.483 h
The estimate for compound 4 lay 3.1-fold (0.49 log units) above the measured number, outside the stated range (below it).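

On the core of compound 3, the swap of 3-(methylsulfonyl)propyl for 3-cyanopropyl gives in this assay a clear drop: a 6.9-fold lower number from compound 3 to compound 4 (0.84 log units; beyond the scatter). This puts the nitrile chain on the lower number on both cores, so the direction of the change carried over in the one further case shown, but the two steps cannot be said to match or differ in size: the same change on two cores in this assay, an at least 1.8-fold lower number (0.25 log units; that floor lies within the scatter) from compound 2 to compound 1 and a 6.9-fold lower number (0.84 log units; beyond the scatter) from compound 3 to compound 4; the limit leaves it open whether they differ. Two pairs are too few to make a rule for other cores, and the first step has only a floor, which leaves no fixed size that could be carried over: the limit of > 1.66 h in this assay, at which 1 of the 4 values shown sits.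

The compounds shown also leave open which part of the difference between the two cores goes with the step, and whether the chain swap would give a similar result on a third core. They do not say how a 3-aminopropyl chain, a chain ending in a carboxylic acid or a longer chain carrying the nitrile would compare in this assay with the 3-(methylsulfonyl)propyl and 3-cyanopropyl chains.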